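The compounds below may be only part of what the source reports. "The series", "measured", "known", "first", "only" and "open" are said of these compounds alone.

Compound 1 `O=C(c1ccccc1)N1CCC(NS(=O)(=O)c2cc(S(=O)(=O)c3ccccc3)ccc2C(F)(F)F)CC1` is the anchor of this small set. In an assay on isolated protein for displacement of a labelled ligand from secreted frizzled-related protein 1 (Homo sapiens), read by fluorescence polarization, with a stated time of 30 min (on this read-out higher numbers stand for weaker inhibition and lower numbers for stronger inhibition), compound 1 gives 70 nM, the lowest of the three numbers measured. Compound 2 `O=C(c1ccc(Cl)nc1)N1CCC(NS(=O)(=O)c2cc(S(=O)(=O)c3ccccc3)ccc2C(F)(F)F)CC1` gives 110 nM in this assay, and the step of a 1.6-fold higher number from compound 1 to compound 2 (0.20 log units; within the scatter) sits within the scatter, so the two stand level. Within the data shown here, compound 3 `CC(C)(C)OC(=O)N1CCC(C(=O)N2CCC(NS(=O)(=O)c3cc(S(=O)(=O)c4ccccc4)ccc3C(F)(F)F)CC2)CC1` gives 300 nM in this assay, a gap from compound 1 that is beyond the scatter; for this pair no single step is tabulated, so only the two values speak.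

Compound 4 `CC(C)(C)OC(=O)N1CC[C@@H](C(=O)N2CCC(NS(=O)(=O)c3cc(S(=O)(=O)c4ccccc4)ccc3C(F)(F)F)CC2)C1` departs from compound 1 in one place: 1-(tert-butoxycarbonyl)pyrrolidin-3-yl in place of phenyl on a carbonyl carbon. Among the measured compounds shown here, the one measured step, a 1.6-fold higher number from compound 1 to compound 2 (0.20 log units; within the scatter), swaps one aromatic ring for another and stays within the scatter, so it bears little on this change. More telling is the pair of values already given: compound 1 gives 70 nM where compound 3, carrying a closely related tert-butoxycarbonyl-substituted ring on the same carbonyl carbon, gives 300 nM. On that basis compound 4 is expected to move the same way, with a step of about a 4.3-fold higher number from compound 1 to compound 4 (0.63 log units; beyond the scatter) towards a higher number. Compound 4 is therefore estimated at 300 nM, with a likely range from 120 nM to 800 nM.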

Compound 4, half-maximal inhibitory concentration: 50 nM
Estimate against measurement, compound 4: 6.0-fold (0.78 log units) above, outside the stated range (below it).
By their numbers in this assay, from the lowest: compounds 4, 1 and 2 (each within the scatter of the next, the first and the last beyond it); then compound 3.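

In this assay the step is a 1.4-fold lower number from compound 1 to compound 4 (0.15 log units; within the scatter), so on this carbonyl carbon a non-aromatic 1-(tert-butoxycarbonyl)pyrrolidin-3-yl group can stand in place of phenyl without a shift beyond the scatter, and an aromatic ring at this place is not required for a number at this level. Set against the other aromatic group, the step is a 2.2-fold lower number from compound 2 to compound 4 (0.34 log units; beyond the scatter), a modest difference that is the only one here to separate compound 4 from a compound with an aromatic ring at this place. Compound 3 gives 300 nM and compound 4 gives 50 nM, so the presence of a tert-butoxycarbonyl group does not by itself go with the higher number, and what it is attached to at this place counts for the result.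

No measurement on hand accounts for these numbers. On these data alone, it remains open whether the tert-butoxycarbonyl group itself is needed, whether a free pyrrolidine amine or a carboxylic acid at this place would hold the number, and whether the defined stereocentre of compound 4 has any bearing on it.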